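A hydroxy group on the outer ring of compound 1

The source may report more compounds than this note shows. Statements on the series, on what has been measured and on what is new or still open speak of the compounds shown alone.

Compound 1 `O=C(O)CC/C=C\CO[C@H]1C(OCc2ccc(-c3ccccc3)cc2)CC[C@@H]1N1CCCCCC1` gives 25.1 nM in a functional assay for antagonist activity at thromboxane A2 receptor (Rattus norvegicus) (on this read-out lower numbers stand for tighter binding and higher numbers for weaker binding), the lower of the two numbers shown, yet a 1.6-fold higher number from compound 1 to compound 2 (0.20 log units; within the scatter) keeps it within the scatter of compound 2 `O=C(O)CC/C=C\CO[C@H]1[C@@H](OCc2ccc(-c3ccccc3)cc2)CC[C@@H]1N1CCCCCC1`, which gives 39.8 nM in this assay. What sets those two apart is the fact that one of compounds 1 and 2 is drawn with a defined configuration and the other without, at the place where they differ. Compound 3 `O=C(O)CC/C=C\CO[C@H]1C(OCc2ccc(-c3ccccc3O)cc2)CC[C@@H]1N1CCCCCC1` differs from compound 1 in a different way: hydroxy in place of hydrogen on an aromatic carbon. Among the measured compounds shown here, the single measured step concerns a stereocentre and does not bear on this change, so no direction beyond the scatter can be drawn from it. Compound 3 is therefore expected to land close to its parent, at an estimated 30 nM with a range of 8 nM to 120 nM, which would mean a 1.2-fold higher number from compound 1 to compound 3 (0.08 log units; within the scatter).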

Compound 3, dissociation constant: 20 nM
Compound 3: the middle estimate sits 1.5-fold (0.18 log units) above what was measured; low and high end bracket the measured number.
By their numbers in this assay, from the lowest: compounds 3, 1 and 2 (each within the scatter of the next).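

The change from phenyl to 2-hydroxyphenyl gives a 1.3-fold lower number from compound 1 to compound 3 (0.10 log units; within the scatter) in this assay. This aromatic carbon, ortho to a large group, therefore takes a hydroxy group without a step beyond the scatter, which the stereocentre step could not show. Nothing in the evidence at hand bears on this hydroxy group.

As far as these compounds go, it remains open whether a methoxy group or an amine at this place would also stay within the scatter of compound 1. From the compounds shown here alone, it is equally open whether the hydroxy group would do so on the defined configuration of compound 2.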